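Removing Chlorine from Two Related Cores

The compounds below may be only part of what the source reports. "The series", "measured", "known", "first", "only" and "open" are said of these compounds alone.

Compound 1 `O=C1C2=C(C(=O)c3ncccc31)C1(CS2)NC(=O)N(c2ccc(Cl)cc2)C1=O` and compound 2 `O=C1C2=C(C(=O)c3ncccc31)C1(CS2)NC(=O)N(c2ccccc2)C1=O` share one core, while compound 3 `O=C1NN(c2ccc(Cl)cc2)C(=O)C2(CSC3=C2C(=O)c2ncccc2C3=O)N1` and compound 4 `O=C1NN(c2ccccc2)C(=O)C2(CSC3=C2C(=O)c2ncccc2C3=O)N1` share another; the difference between the two cores is not broken down here. In a functional assay on HeLa cells (Homo sapiens) for antiproliferative activity, read by MTT assay, with a stated time of 96 h (a higher number here means a weaker inhibitor, a lower number a stronger inhibitor), compound 1 gives 2 nM and compound 2 gives 3 nM. The step of a 1.5-fold higher number from compound 1 to compound 2 (0.18 log units; within the scatter) corresponds to the change (hydrogen in place of chloro on an aromatic carbon). Compound 3 gives 150 nM in this assay. Compound 4 is not yet measured; it differs from compound 3 by hydrogen in place of chloro on an aromatic carbon, the same change as that between compound 1 and compound 2. Because the measured step of a 1.5-fold higher number from compound 1 to compound 2 (0.18 log units; within the scatter) stayed within the scatter, a similar step a 1.3-fold higher number from compound 3 to compound 4 (0.12 log units; within the scatter) is expected here. Compound 4 is therefore estimated at 200 nM, between 80 nM and 500 nM.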

Compound 4, half-maximal inhibitory concentration: 210 nM
Compound 4: middle estimate off by 1.1-fold (0.02 log units), on the low side; the measured number falls inside the stated range.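

In this assay, going from the 4-chlorophenyl to the phenyl group gives a 1.4-fold higher number from compound 3 to compound 4 (0.15 log units; within the scatter), and the same change gives closely matching steps on the two cores: the same change on two cores in this assay, a 1.5-fold higher number (0.18 log units; within the scatter) from compound 1 to compound 2 and a 1.4-fold higher number (0.15 log units; within the scatter) from compound 3 to compound 4, 1.1-fold (0.03 log units) apart, within the scatter of two such steps. On these two cores, then, swapping chloro for hydrogen moved the result no further than repeat measurements normally scatter, and the size of the step carried over from one core to the other. Among the compounds shown here, this rests on only two pairs of compounds, so it shows nothing about other cores and does not explain why the two steps agree.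

On these data alone, only chloro and hydrogen appear at this place on the ring, so it remains open how a methoxy group, an amine or a carboxylic acid there would behave. As far as these compounds go, it also remains open whether such groups would give matching steps on the two cores.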